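Piperazine nitrogen substituent and HeLa antiproliferative response

The source may report more compounds than this note shows. Statements on the series, on what has been measured and on what is new or still open speak of the compounds shown alone.

Measured compounds:
compound 1, `Nc1ccccc1NC(=O)c1ccc(CSC(=S)N2CCN(c3ccncc3)CC2)cc1`: 77%
compound 2, `Nc1ccccc1NC(=O)c1ccc(CSC(=S)N2CCN(Cc3ccccc3)CC2)cc1`: 20.6%
compound 3, `Nc1ccccc1NC(=O)c1ccc(CSC(=S)N2CCN(c3cccnc3)CC2)cc1`: 66.2%

All three share one core and differ only in the group on an amine nitrogen in a ring. In a functional assay on HeLa cells (Homo sapiens) for antiproliferative activity, read by CCK-8 assay, with a stated time of 72 h, tested at 2 uM (a lower number here means a weaker effect, a higher number a stronger effect of the compound at the concentration tested), compound 3 holds the second highest of the three numbers; its nearest neighbour is compound 1, the step of a number 10.8 percentage points lower from compound 1 to compound 3 (beyond the scatter), and its furthest is compound 2, the step of a number 45.6 percentage points higher from compound 2 to compound 3 (beyond the scatter).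

Compound 4, `CN1CCN(C(=S)SCc2ccc(C(=O)Nc3ccccc3N)cc2)CC1`, is not yet measured. It differs from compound 3 as follows: methyl in place of pyridin-3-yl on an amine nitrogen in a ring.

Among the measured compounds shown here, two measured steps bear on it. Replacing an aromatic six-membered ring on that nitrogen by benzyl gave a number 56.4 percentage points lower from compound 1 to compound 2 (beyond the scatter), and the reverse exchange gave a number 45.6 percentage points higher from compound 2 to compound 3 (beyond the scatter). Both show that the aryl group on the ring nitrogen carries much of the effect in this assay. For the measured compounds named here, no measured step removes the ring entirely in favour of methyl, so the size is uncertain, but a step downward beyond the scatter is expected, estimated as a number 34.2 percentage points lower from compound 3 to compound 4 (beyond the scatter).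

Compound 4 is therefore expected to give about 32% in this assay, within a range from 12% to 58%.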

Compound 4, a percentage reported as inhibition, at one concentration (the size of the read-out at that concentration, not a potency): 52.6%
Compound 4: middle estimate off by 20.6 percentage points, on the low side, within the range that was stated.
By their numbers in this assay, from the lowest: compound 2; then compound 4; then compound 3; then compound 1.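

In this assay, methyl in place of the six-membered aromatic ring on the amine nitrogen in a ring costs only a modest amount: a number 13.6 percentage points lower from compound 3 to compound 4 (beyond the scatter) and a number 24.4 percentage points lower from compound 1 to compound 4 (beyond the scatter), so an aromatic ring at this position is not required for a substantial response, although both pyridinyl compounds still lie above the methyl compound. The position also does not follow substituent size in a simple way, as the smallest group here outperforms the benzyl group, with hydrogen in place of phenyl on the saturated chain carbon giving a number 32 percentage points higher from compound 2 to compound 4 (beyond the scatter); the low response of compound 2 therefore goes with the phenyl carried on that carbon, not with the mere absence of a pyridinyl ring. No available evidence bears on what underlies these differences.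

On these data alone, whether a hydrogen on the ring nitrogen, an ethyl group, a longer chain or a phenyl ring attached directly would fall with methyl, with benzyl or with the pyridinyl groups remains open. The series is also read at a single concentration in one cell line, which leaves open whether this order would hold as a potency order or in other cells.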